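This account rests on a few compounds, and the source may have more. Where it says the series, first, only, none or still open, it means among the compounds named here.

Of the compounds shown here, three sharing one core have been measured in a physicochemical assay, with a stated time of 30 min (on this read-out higher numbers stand for weaker inhibition and lower numbers for stronger inhibition), and compound 2 `COc1cccc(NC(=O)C2Cc3cc(OC)c(OC)cc3C2=O)c1` gives 38.9 ug/mL there. Compound 1 `COc1cc2c(cc1OC)C(=O)C(C(=O)Nc1ccc(Br)cc1)C2` gives 72.1 ug/mL and compound 3 `CCOc1cccc(NC(=O)C2Cc3cc(OC)c(OC)cc3C2=O)c1` gives 44.9 ug/mL in this assay and compound 2 stands within the scatter of both, so no order can be read among them. The change in question leads to compound 4 `COc1cc2c(cc1OC)C(=O)C(C(=O)Nc1ccccc1F)C2` and is 2-fluorophenyl in place of 3-methoxyphenyl on an amide-type nitrogen with 2-fluorophenyl in place of 3-methoxyphenyl on an amide-type nitrogen. The closest measured precedent lies at that same nitrogen and amounts to a 1.9-fold lower number from compound 1 to compound 2 (0.27 log units; within the scatter) when 3-methoxyphenyl replaces 4-bromophenyl. The other measured step amounts to a 1.2-fold higher number from compound 2 to compound 3 (0.06 log units; within the scatter) with methyl in place of hydrogen on a saturated chain carbon bound to an oxygen on an aromatic ring. Within the data shown here, both steps stay within the scatter, but no measured compound carries 2-fluorophenyl, so the data offer no direct precedent for it. Given a 1.9-fold lower number from compound 1 to compound 2 (0.27 log units; within the scatter) at that nitrogen, no step beyond the scatter is expected, and no direction is favoured. The estimated change is a 1.3-fold higher number from compound 2 to compound 4 (0.11 log units; within the scatter) and it is expected to stay within the scatter. Compound 4 is expected at 50 ug/mL with an estimated range from 24 ug/mL to 105 ug/mL on this reasoning.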

Compound 4, half-maximal inhibitory concentration: 75.7 ug/mL
Compound 4: middle estimate off by 1.5-fold (0.18 log units), on the low side; measured number inside the range.
By their numbers in this assay, from the lowest: compounds 2, 3, 1 and 4 (each within the scatter of the next).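

In this assay, the change at the amide-type nitrogen gives a 1.9-fold higher number from compound 2 to compound 4 (0.29 log units; within the scatter) as 2-fluorophenyl replaces 3-methoxyphenyl, so exchanging a group that has a hydrogen-bond acceptor for one that has none produces no step beyond the scatter. The other new step, with 2-fluorophenyl in place of 4-bromophenyl, is a 1.0-fold higher number from compound 1 to compound 4 (0.02 log units; within the scatter) and leaves these two groups indistinguishable on this read-out. With a third substituted phenyl group now at this nitrogen, none of the steps among compounds 1, 2 and 4 goes beyond the scatter, and nothing presented offers an explanation for these values.

Going by these compounds, whether any group at this nitrogen could give a step beyond the scatter remains open, for example a saturated alkyl chain, a pyridine ring, or a phenyl ring carrying an amine or a carboxylic acid. Also open is how the number would respond to a change in the shared core itself, such as replacing its methoxy groups with hydroxyl groups or altering its carbonyl, as every compound shown keeps these parts unchanged.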